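From compound 3 to compound 4: one ring group exchanged

A few compounds are considered here, and "the series" means these few. Any claim that something is new, unique, unknown or untested is made for them only; others in the source may bear on it.

In a physicochemical assay for solubility, measured as kinetic solubility, at pH 2 (on this read-out lower numbers stand for lower solubility and higher numbers for higher solubility), compound 1 `CC(C)C(/C=C1\NC(=O)NC1=O)c1ccc(-c2ccc3cccc(F)c3c2)[nH]c1=O` gives 7500 nM while compound 2 `CC(C)C(c1ccc(-c2ccc3cccc(F)c3c2)[nH]c1=O)C1NC(=O)NC1=O` gives 5800 nM and compound 3 `CC(C)C(/C=C1\SC(=O)NC1=O)c1ccc(-c2ccc3cccc(F)c3c2)[nH]c1=O` gives 4800 nM on the same read-out. Compound 3 therefore stands within the scatter of both others. Compound 4 `CC(C)C(c1ccc(-c2ccc3cccc(F)c3c2)[nH]c1=O)C1C(=O)NC(=O)N1C` carries 3-methyl-2,5-dioxoimidazolidin-4-yl on a saturated chain carbon bound to an aromatic carbon and a saturated chain carbon, and the change is a group of 8 heavy atoms (4 carbon, 2 nitrogen, 2 oxygen; one five-membered non-aromatic ring with 2 hetero atoms) in place of a group of 8 heavy atoms (4 carbon, 1 nitrogen, 2 oxygen, 1 sulfur; one five-membered non-aromatic ring with 2 hetero atoms), on a saturated chain carbon bound to an aromatic carbon and a saturated chain carbon in this one place. Three measured exchanges at that place bear on it, namely a 1.3-fold lower number from compound 1 to compound 2 (0.11 log units; within the scatter) and a 1.6-fold lower number from compound 1 to compound 3 (0.19 log units; within the scatter) and also a 1.2-fold lower number from compound 2 to compound 3 (0.08 log units; within the scatter) as their sizes. Among the measured compounds shown here, no measured step isolates the methyl group. In this assay the expected move is a 1.1-fold higher number from compound 3 to compound 4 (0.06 log units; within the scatter) and so none beyond the scatter. For compound 4 the estimated value is 5500 nM with an expected range from 3000 nM to 10000 nM in this measurement.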

Compound 4, solubility: 13600 nM
For compound 4 the middle estimate is 2.5-fold (0.39 log units) below the measured one; the measured number lies above the stated range.
By their numbers in this assay, from the lowest: compounds 3, 2, 1 and 4 (each within the scatter of the next, the first and the last beyond it).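

In this assay, among the compounds shown here, the methyl group is isolated for the first time: methyl in place of hydrogen on an amide-type nitrogen in a ring gives a step beyond the scatter (a 2.3-fold higher number from compound 2 to compound 4 (0.37 log units; beyond the scatter)), which no earlier exchange at this position did. The ring exchange also goes beyond it (a 2.8-fold higher number from compound 3 to compound 4 (0.45 log units; beyond the scatter)), whereas the third step stays within it (a 1.8-fold higher number from compound 1 to compound 4 (0.26 log units; within the scatter)). Nothing available explains these steps. On these data alone, whether an ethyl group, a longer chain or a carboxylic acid in place of that methyl would give a similar number remains open.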